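Swapping the anilino arm of compound 1 for an ester-bearing piperidine

The compounds below may be only part of what the source reports. "The series", "measured", "known", "first", "only" and "open" are said of these compounds alone.

Three compounds that share one core have been run through a functional assay on CHO-K1 cells for antagonist activity at transient receptor potential cation channel subfamily V member 1 (Homo sapiens), read by FLIPR; a lower number here means a stronger inhibitor, a higher number a weaker inhibitor. Compound 1, `CC(C(=O)NCc1ccc(C(F)(F)F)nc1N(C)c1ccccc1)c1ccc(NS(C)(=O)=O)c(F)c1`, gives 57.4 nM. Compound 3, `C[C@H](C(=O)NCc1ccc(C(F)(F)F)nc1N1CCC(c2ccccc2)CC1)c1ccc(NS(C)(=O)=O)c(F)c1`, gives 17.4 nM, and the gap between compound 3 and compound 1 lies beyond the scatter, so compound 1 stands as the higher of the two numbers reported. Compound 2, `C[C@H](C(=O)NCc1ccc(C(F)(F)F)nc1N1CCC[C@H]1C(=O)N(C)C)c1ccc(NS(C)(=O)=O)c(F)c1`, is recorded as "not active" (no number reported) in this assay , with no number attached.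

Compound 4, `CC(=O)OC1CCN(c2nc(C(F)(F)F)ccc2CNC(=O)C(C)c2ccc(NS(C)(=O)=O)c(F)c2)CC1`, has not yet been measured. It differs from compound 1 in one place: 4-acetoxypiperidin-1-yl in place of methyl(phenyl)amino on an aromatic carbon. For the measured compounds named here, no measured pair isolates this particular exchange, so the only guide is that a phenyl-bearing piperidine in compound 3 sits at a lower number than compound 1, whereas a pyrrolidine carrying an amide in compound 2 gave no number at all. The 4-acetoxypiperidin-1-yl group resembles the latter more than the former in what it carries, so a weakening step is expected, estimated at a 3.5-fold higher number from compound 1 to compound 4 (0.54 log units; beyond the scatter) in this assay . Compound 4 is accordingly expected to give about 200 nM, within a range of 50 nM to 1000 nM.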

Compound 4, half-maximal inhibitory concentration: 139 nM
Compound 4: the middle estimate sits 1.4-fold (0.16 log units) above what was measured; the range from low to high includes it.
By their numbers in this assay, from the lowest: compound 3; then compound 1; then compound 4.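

In this assay, for the compounds shown here, this is the first exchange at this position that can be read in one place: on the aromatic carbon next to the ring nitrogen, 4-acetoxypiperidin-1-yl in place of methyl(phenyl)amino gives a 2.4-fold higher number from compound 1 to compound 4 (0.38 log units; beyond the scatter). The change removes the six-membered aromatic ring of carbon only and brings in a non-aromatic ring carrying an acetoxy group, yet the loss stays modest and compound 4 still gives 139 nM, so this position accepts an exchange of that kind with a measurable result. Nothing measured here accounts for the size or direction of this step.

The compounds shown leave open whether the step follows the piperidine ring or the acetoxy group on it, and a plain piperidin-1-yl, or a piperidine carrying a hydroxyl or methoxy group in place of the acetoxy group, would separate the two. Also open, as far as these compounds go, is how a piperidine carrying an amine or a carboxylic acid in place of the acetoxy group would read in this assay.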